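The source may hold more compounds than are shown below. What is called first, only, known or untested is meant among the compounds shown, and "the series" means these compounds.

Measured so far:
compound 1 `N#Cc1ccc(/C=C2\Cc3cc(O)ccc3C2=O)cc1` – 2080 nM
compound 2 `CN(C)c1ccc(/C=C2\Cc3cc(O)ccc3C2=O)cc1` – 1720 nM

In an assay on isolated protein for inhibition of Amine oxidase [flavin-containing] A (Homo sapiens), read by fluorescence and spectrophotometry, with a stated time of 20 min (on this read-out lower numbers stand for stronger inhibition and higher numbers for weaker inhibition), compound 2 gives 1720 nM and compound 1 gives 2080 nM; the step of a 1.2-fold lower number from compound 1 to compound 2 (0.08 log units; within the scatter) lies within the scatter, so compound 2 stands level with its only comparator. Compound 3 `CC(C)c1ccc(/C=C2\Cc3cc(O)ccc3C2=O)cc1` carries isopropyl in place of dimethylamino on an aromatic carbon. For the measured compounds named here, the one measured step that bears on this change, a 1.2-fold lower number from compound 1 to compound 2 (0.08 log units; within the scatter), swapped the group at the same place and did not move the number beyond the scatter. A step of no more than the scatter is therefore expected for this assay, without a clear direction. Compound 3 is estimated at 1900 nM, range 800 nM to 4500 nM, corresponding to an expected 1.1-fold higher number from compound 2 to compound 3 (0.04 log units; within the scatter).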

Compound 3, half-maximal inhibitory concentration: 961 nM
Compound 3: middle estimate off by 2.0-fold (0.30 log units), on the high side; measured number inside the range.
By their numbers in this assay, from the lowest: compounds 3, 2 and 1 (each within the scatter of the next, the first and the last beyond it).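

In this assay, isopropyl in place of dimethylamino on this aromatic carbon stays within the scatter, with a 1.8-fold lower number from compound 2 to compound 3 (0.25 log units; within the scatter). Isopropyl in place of cyano is the first change at this position to pass the scatter, though only modestly, with a 2.2-fold lower number from compound 1 to compound 3 (0.34 log units; beyond the scatter), so the series now holds its first separated pair. Nothing available here explains this separation.

Open, from the compounds shown here alone, is whether a longer alkyl chain, such as tert-butyl or n-butyl, would separate further from compound 1. Also open, going by these compounds, is how a carboxylic acid or a primary amine on the same carbon would compare.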